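A few compounds are considered here, and "the series" means these few. Any claim that something is new, unique, unknown or untested is made for them only; others in the source may bear on it.

Compound 2 `CCS(=O)(=O)N1CCC(Oc2ncnc3c2CCN3c2ccc(S(C)(=O)=O)cc2F)CC1` holds the highest of the two numbers in a functional assay on CHO-K1 cells for agonist activity at Glucose-dependent insulinotropic receptor (Homo sapiens), read by a luciferase reporter, with a stated time of 5 h; a lower number here means that less compound is needed, a higher number that more compound is needed for the effect: compound 2 gives 1580 nM. Its nearest neighbour, compound 1 `CC(C)(C)OC(=O)N1CCC(Oc2ncnc3c2CCN3c2ccc(S(C)(=O)=O)cc2F)CC1`, gives 20 nM in this assay. Going by the values given here, the single measured step, a 79-fold higher number from compound 1 to compound 2 (1.90 log units; beyond the scatter), was large. Compound 3 `CN(C)S(=O)(=O)N1CCC(Oc2ncnc3c2CCN3c2ccc(S(C)(=O)=O)cc2F)CC1` keeps the sulfonyl and differs from compound 2 only in that (dimethylamino in place of ethyl on a sulfonyl sulfur). Among the compounds with values here, no measured step bears on this exchange; the one known step concerns tert-butoxycarbonyl against ethylsulfonyl, which compound 3 does not touch. The expected step is therefore a 1.0-fold higher number from compound 2 to compound 3 (0.01 log units; within the scatter), none beyond the scatter. Compound 3 is estimated at 1600 nM, between 500 nM and 5000 nM.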

Compound 3, half-maximal effective concentration: 398 nM
For compound 3 the middle estimate is 4.0-fold (0.60 log units) above the measured one, outside the stated range (below it).
By their numbers in this assay, from the lowest: compound 1; then compound 3; then compound 2.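

In this assay, the group on the sulfonyl sulfur matters: dimethylamino in place of ethyl gives a 4.0-fold lower number from compound 2 to compound 3 (0.60 log units; beyond the scatter). Dimethylsulfamoyl still does not match tert-butoxycarbonyl on the amine nitrogen in a ring, with a 20-fold higher number from compound 1 to compound 3 (1.30 log units; beyond the scatter). Nothing available explains either step. From the compounds shown here alone, it remains open whether a longer chain such as propyl, or a cyclic amine such as pyrrolidine, on the sulfonyl sulfur would lower the number further. Also open, going by these compounds, is how other carbamates, such as the isopropyl carbamate, would compare with tert-butoxycarbonyl.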